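This account rests on a few compounds, and the source may have more. Where it says the series, first, only, none or still open, it means among the compounds named here.

Of the compounds shown here, three built on one shared core have been tested in a functional assay on K562/Adr cells (Homo sapiens) for inhibition, read by MTT assay, with a stated time of 48 h, tested at 30 uM; on this read-out higher numbers stand for more inhibition at the one concentration tested (going by the name of the read-out) and lower numbers for less inhibition. Compound 1 `Nc1n[nH]c2cc(-c3cn([C@@H]4CN[C@H](C(=O)Nc5ccc(Cl)c(C(F)(F)F)c5)C4)nn3)ccc12` gives 48.2%. Compound 2 `O=C(Nc1n[nH]c2cc(-c3cn([C@@H]4CN[C@H](C(=O)Nc5ccc(Cl)cc5Cl)C4)nn3)ccc12)C1CC1` gives 43.3%. Compound 3 `Nc1n[nH]c2cc(-c3cn([C@@H]4CN[C@H](C(=O)Nc5ccc(Br)cc5)C4)nn3)ccc12` gives 26.8%, the lowest of the three numbers, with compound 2 as its nearest neighbour and compound 1 as its furthest. Going by the values given here, the one single-point step among the measured compounds is a number 21.4 percentage points lower from compound 1 to compound 3 (beyond the scatter), which goes with 4-bromophenyl in place of 4-chloro-3-(trifluoromethyl)phenyl on an amide-type nitrogen.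

Compound 4 `O=C(Nc1n[nH]c2cc(-c3cn([C@@H]4CN[C@H](C(=O)Nc5ccc(Br)cc5)C4)nn3)ccc12)C1CC1` has not yet been measured in this assay. It differs from compound 3 in one place: cyclopropylcarbonyl in place of hydrogen on a nitrogen on an aromatic ring. Among the compounds with values here, no measured pair isolates this change. Compound 1 and compound 2 differ from each other in this way and in the aryl group at the same time, so only their two values can be set side by side, and those two values lie within the scatter of one another. On that thin basis the step of a number 3.2 percentage points higher from compound 3 to compound 4 (within the scatter) is expected to stay within the scatter, in no clear direction. The estimate for compound 4 in this assay is 30%, with a range from 15% to 48%.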

Compound 4, a percentage reported as inhibition, at one concentration (the size of the read-out at that concentration, not a potency): 39.6%
For compound 4 the middle estimate is 9.6 percentage points below the measured one; the range from low to high includes it.
By their numbers in this assay, from the lowest: compound 3; then compounds 4, 2 and 1 (each within the scatter of the next).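

Going by these compounds alone, with the 4-bromophenyl amide held fixed, this is the first pair in which the nitrogen on the aromatic ring changes alone, and in this assay going from amino to (cyclopropylcarbonyl)amino gives a number 12.8 percentage points higher from compound 3 to compound 4 (beyond the scatter), so a free amino group at this place is not required for inhibition at the one concentration tested, and acylation here goes with a higher number. With the cyclopropylcarbonyl group present in both compounds, the aryl change gives a number 3.7 percentage points lower from compound 2 to compound 4 (within the scatter), so 4-bromophenyl and 2,4-dichlorophenyl cannot be told apart on this read-out. Nothing available explains why the acylated compound reads higher than its amino parent.

From the compounds shown here alone, it remains open whether this step belongs to the cyclopropylcarbonyl group itself or would also appear with a plain acetyl group, a longer acyl chain such as butanoyl, or a methanesulfonyl group on the same nitrogen. Going by these compounds, it also remains open whether the step carries over to other aryl groups, since it rests on a single pair with 4-bromophenyl, and a single-concentration percentage says nothing about potency.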